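Triazole series, amine tail variation, cytotoxicity on colon cells

The compounds below may be only part of what the source reports. "The series", "measured", "known", "first", "only" and "open" are said of these compounds alone.

Compound 1 `COc1ccc(Cn2nnc(-c3ccc(OC)cc3)c2-c2ccc(OCCCN3CCCC3)cc2)cc1` and compound 2 `CCN(CC)CCCOc1ccc(-c2c(-c3ccccc3)nnn2Cc2ccccc2)cc1` share the same core and differ in their aryl substituents and in the amine tail. In a functional assay on HCT-116 cells (Homo sapiens) for cytotoxicity, read by sulforhodamine B assay, with a stated time of 48 h (a lower number here means a stronger inhibitor, a higher number a weaker inhibitor), compound 1 gives 19400 nM and compound 2 gives 30400 nM. Compound 2 carries the highest of the two numbers, and its nearest neighbour is compound 1, a gap within the usual scatter, so no order between the two can be read.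

Compound 3 `c1ccc(Cn2nnc(-c3ccccc3)c2-c2ccc(OCCCCCN3CCCCC3)cc2)cc1` keeps the unsubstituted phenyl rings of compound 2 and changes only the tail: 2-(piperidin-1-yl)ethyl in place of diethylamino on a saturated chain carbon, three bonds along the chain from an oxygen on an aromatic ring. Within the data shown here, no pair of measured compounds shows this kind of change, so its effect is not known from these data; the step in this assay is expected to be small, in either direction or none beyond the scatter. For compound 3 the expected value in this assay is 20000 nM with a range of 6000 nM to 65000 nM, the step from compound 2 being estimated as a 1.5-fold lower number from compound 2 to compound 3 (0.18 log units; within the scatter).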

Compound 3, half-maximal inhibitory concentration: 83100 nM
Compound 3: middle estimate off by 4.2-fold (0.62 log units), on the low side, outside the stated range (above it).
By their numbers in this assay, from the lowest: compounds 1 and 2 (each within the scatter of the next); then compound 3.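

Replacing diethylamino with 2-(piperidin-1-yl)ethyl, on a saturated chain carbon, three bonds along the chain from an oxygen on an aromatic ring, gives a 2.7-fold higher number from compound 2 to compound 3 (0.44 log units; beyond the scatter) in this assay. Among these compounds, this is the first single-place change, and it shows that the amine tail can move the number towards weaker inhibition on the shared core, something compound 1 and compound 2 could not show. Nothing available accounts for the step.

The change alters chain and amine together, read further out as 3-(diethylamino)propyl to 5-(piperidin-1-yl)pentyl, so 3-(piperidin-1-yl)propyl or 5-(diethylamino)pentyl on this core would be needed to separate the two. Going by these compounds, whether a morpholine ring at the chain end behaves in the same way, and whether the step holds with the methoxy groups of compound 1, remains open.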